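A few compounds are considered here, and "the series" means these few. Any claim that something is new, unique, unknown or untested is made for them only; others in the source may bear on it.

Compounds measured so far in an ADME assay on Huh-7 cells (Homo sapiens) for cytotoxicity; on this read-out lower numbers stand for higher toxicity in this test and higher numbers for lower toxicity in this test:

- compound 1, `O=c1cc(CNCc2cccc(F)c2)oc2ccc(O)c(O)c12`, gives > 100000 nM, a limit of the assay.
- compound 2, `O=c1cc(CNCc2cccc(Cl)c2)oc2ccc(O)c(O)c12`, gives > 100000 nM, a limit of the assay.
- compound 3, `O=c1cc(CNCc2cccc(I)c2)oc2ccc(O)c(O)c12`, gives > 100000 nM, a limit of the assay.

Compound 3 therefore stands at the assay limit, and the two other values shown stand there too (the limit of > 100000 nM in this assay, at which 3 of the 3 values shown sit); no number separates any of the three. The steps among them, a step that the two limits leave unreadable from compound 1 to compound 2, a step that the two limits leave unreadable from compound 1 to compound 3 and a step that the two limits leave unreadable from compound 2 to compound 3, are all unreadable in size, since each joins two limits.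

Compound 4, `O=c1cc(CNCc2cccc([N+](=O)[O-])c2)oc2ccc(O)c(O)c12`, differs from compound 3 in one place: nitro in place of iodo on an aromatic carbon. The three measured steps bear on this change only in that they vary the same position on the same ring and give no readable movement. A step in this assay from compound 3 to compound 4 is therefore expected to be none beyond the scatter, a step that the limit leaves unreadable from compound 3 to compound 4, and most likely to end again at the limit. The estimate for compound 4 in this assay is 150000 nM, within a range from 50000 nM to 400000 nM.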

Compound 4, half-maximal cytotoxic concentration: > 100000 nM
Compound 4: no number, only a limit; the forecaster's own chance of this, stated with the estimate: 75%; the middle value does not contradict the limit.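

In this assay compound 4 gives > 100000 nM, a limit of the assay. The steps from compound 1, compound 2 and compound 3 to compound 4 cannot be read, and all four values share one limit: the limit of > 100000 nM in this assay, at which 4 of the 4 values shown sit.

The compounds shown leave open whether the fluoro, chloro, iodo and nitro compounds differ at all in this assay.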